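The compounds below may be only part of what the source reports. "The series", "measured", "known", "first", "only" and "open" are said of these compounds alone.

Measured so far:
compound 1 `CC(C)(C)n1ncc(OCc2nnc(-c3cc(F)c(Cl)cc3Cl)s2)c(Cl)c1=O` — 67100 nM
compound 2 `CC(C)(C)n1ncc(OCc2nnc(-c3ccccc3)o2)c(Cl)c1=O` — 12200 nM

In a functional assay on the whole organism for inhibition, with Mythimna separata as the target, with a stated time of 5 days (a higher number here means that more compound is needed for the effect, a lower number that less compound is needed), compound 1 gives 67100 nM, the highest of the two numbers; compound 2 gives 12200 nM, a lower number, beyond the scatter. Compound 3 `CC(C)(C)n1ncc(OCc2nnc(-c3ccc(F)cc3)s2)c(Cl)c1=O` is not yet measured. It differs from compound 1 by 4-fluorophenyl in place of 2,4-dichloro-5-fluorophenyl on an aromatic carbon. Among the compounds with values here, no measured pair isolates this change. A moderate downward step is expected, because compound 2, with an unsubstituted phenyl, gives 12200 nM. The step from compound 1 to compound 3 in this assay is expected to be a 2.7-fold lower number from compound 1 to compound 3 (0.43 log units; beyond the scatter). Compound 3 is estimated at 25000 nM, between 8000 nM and 70000 nM.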

Compound 3, half-maximal effective concentration: 21500 nM
Compound 3: middle estimate off by 1.2-fold (0.07 log units), on the high side; the measured number falls inside the stated range.
By their numbers in this assay, from the lowest: compounds 2 and 3 (each within the scatter of the next); then compound 1.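

In this assay, within the data shown here, replacing 2,4-dichloro-5-fluorophenyl with 4-fluorophenyl on the aromatic carbon gives a 3.1-fold lower number from compound 1 to compound 3 (0.49 log units; beyond the scatter), the first single-place step. The group at this position therefore affects the number, and the chlorine-free group gives the lower value of this pair. No measured property is available to account for the step.

The step changes the chlorines and the fluorine together, so the share of each halogen remains unresolved. Also open, from the compounds shown here alone, is how a methoxy group or a nitrile on this phenyl ring would read.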